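Amide substituent swap on the dilipidated cysteine core

The source may report more compounds than this note shows. Statements on the series, on what has been measured and on what is new or still open speak of the compounds shown alone.

Compound 2 `CCCCCCCCCCCC(=O)OC[C@H](CSC[C@@H](N)C(=O)NCCCCCC(=O)O)OC(=O)CCCCCCCCCCC` stands lowest of the two numbers measured in an assay on HEK293 cells for agonist activity at Toll-like receptor 2 (Homo sapiens); on this read-out higher numbers stand for an effect only at larger amounts of compound and lower numbers for an effect already at smaller amounts; compound 2 gives 108 nM, while compound 1 `CCCCCCCCCCCC(=O)OC[C@H](CSC[C@@H](N)C(=O)NC(C)c1ccc(O)cc1)OC(=O)CCCCCCCCCCC` gives 2890 nM. Compound 3 `CCCCCCCCCCCC(=O)OC[C@H](CSC[C@@H](N)C(=O)NCCN)OC(=O)CCCCCCCCCCC` carries amino in place of 3-carboxypropyl on a saturated chain carbon, two bonds along the chain from an amide-type nitrogen. Going by the values given here, the only measured step that touches the substituent on the amide nitrogen is a 27-fold lower number from compound 1 to compound 2 (1.43 log units; beyond the scatter), showing that this part of the molecule can move the read-out strongly. Among the compounds with values here, no measured step exchanges an acid terminus for an amine, so the direction is open; a moderate shift toward higher numbers is expected, a 2.3-fold higher number from compound 2 to compound 3 (0.36 log units; beyond the scatter). Compound 3 is estimated at 250 nM in this assay, within 40 nM to 2500 nM.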

Compound 3, half-maximal effective concentration: 5240 nM
Estimate against measurement, compound 3: 21-fold (1.32 log units) below, and the stated range ends below it.
By their numbers in this assay, from the lowest: compound 2; then compounds 1 and 3 (each within the scatter of the next).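

In this assay, amino in place of 3-carboxypropyl gives a 49-fold higher number from compound 2 to compound 3 (1.69 log units; beyond the scatter), so this place on the chain can move the read-out at least as strongly as the earlier amide-nitrogen swap did. With a 1.8-fold higher number from compound 1 to compound 3 (0.26 log units; within the scatter), 2-aminoethyl and 1-(4-hydroxyphenyl)ethyl on the amide-type nitrogen cannot be told apart. Nothing available explains the large step. This change alters chain length and terminal group together, leaving their separate contributions open. A 5-aminopentyl chain, with the amine at the full chain length, or a carboxymethyl group, with the acid on a short chain, would separate them.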